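This account rests on a few compounds, and the source may have more. Where it says the series, first, only, none or still open, it means among the compounds named here.

Measured in a functional assay on MT4 cells (Homo sapiens) for cytotoxicity, read by MTT assay; a higher number here means that more compound is tolerated, a lower number that less compound is tolerated:

- Compound 1 `Cc1c(O)nc(Sc2ccc(F)cc2F)nc1Cc1c(F)cccc1F`: > 65800 nM
- Compound 2 `Cc1c(O)nc(Sc2ccccc2)nc1Cc1c(F)cccc1F`: > 72700 nM
- Compound 3 `Cc1c(O)nc(Sc2ccc(Cl)cc2)nc1Cc1c(F)cccc1F`: > 66100 nM

Each of these three entries is a limit and not a number. Compound 3 stands at > 66100 nM, which is a limit. Compound 4 `COc1ccc(Sc2nc(O)c(C)c(Cc3c(F)cccc3F)n2)cc1` carries methoxy in place of chloro on an aromatic carbon, para to a large group (methoxy in place of chloro on an aromatic carbon). The closest measured changes are a step that the two limits leave unreadable from compound 2 to compound 3 and a step that the two limits leave unreadable from compound 1 to compound 3, and a step that the two limits leave unreadable from compound 1 to compound 2 adds no size either. With no readable size to carry over, no step beyond the usual scatter is expected in this assay, in either direction, and another limit is likely. The expected result is a step that the limit leaves unreadable from compound 3 to compound 4. For compound 4 the estimate is 67000 nM, with an expected range of 35000 nM to 130000 nM.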

Compound 4, half-maximal cytotoxic concentration: 57500 nM
Compound 4: middle estimate off by 1.2-fold (0.07 log units), on the high side; low and high end bracket the measured number.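

In this assay, within the data shown here, methoxy on an aromatic carbon, para to a large group, gives the first real number in this set rather than a limit. Against the other compounds this reads as an at least 1.1-fold lower number from compound 3 to compound 4 (0.06 log units; that floor lies within the scatter), an at least 1.2-fold lower number from compound 2 to compound 4 (0.10 log units; that floor lies within the scatter) and an at least 1.1-fold lower number from compound 1 to compound 4 (0.05 log units; that floor lies within the scatter), while the steps among the first three compounds cannot be read. Each of these new steps is only a floor, because its starting value is a limit, as for compound 3: the limit of > 66100 nM in this assay, at which 1 of the 4 values shown sits.

From the compounds shown here alone, whether an amine or a carboxylic acid at this position would give a step beyond the scatter remains open. So does the true size of the methoxy step.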